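Replacing the aryl group on the sulfonyl sulfur of compound 1

The source may report more compounds than this note shows. Statements on the series, on what has been measured and on what is new or still open speak of the compounds shown alone.

Compound 1 `O=C(NCc1ccc(S(=O)(=O)c2cccc(C(F)(F)F)c2)cc1)N1Cc2ccncc2C1` gives 2.7 nM in a functional assay on A2780 cells (Homo sapiens) for cytotoxicity, read by sulforhodamine B assay, with a stated time of 72 h (a lower number here means a stronger inhibitor, a higher number a weaker inhibitor), the lowest number among the three measured compounds. Compound 2 `O=C(NCc1ccc(S(=O)(=O)C2CCOCC2)cc1)N1Cc2ccncc2C1` gives 35 nM and compound 3 `O=C(NCc1ccc(S(=O)(=O)N2CCOCC2)cc1)N1Cc2ccncc2C1` gives 68 nM. The two steps away from compound 1 were both large: a 13-fold higher number from compound 1 to compound 2 (1.11 log units; beyond the scatter) and a 25-fold higher number from compound 1 to compound 3 (1.40 log units; beyond the scatter), while a 1.9-fold higher number from compound 2 to compound 3 (0.29 log units; within the scatter). Compound 4 `CN1CCN(S(=O)(=O)c2ccc(CNC(=O)N3Cc4ccncc4C3)cc2)CC1` differs from compound 1 in one place: 4-methylpiperazin-1-yl in place of 3-(trifluoromethyl)phenyl on a sulfonyl sulfur. Both earlier exchanges of the 3-(trifluoromethyl)phenyl group for a six-membered non-aromatic ring raised the number well beyond the scatter, and the morpholin-4-yl case in compound 3 resembles the present change most closely. Compound 4 is therefore expected to give a higher number, around 100 nM with a range of 30 nM to 400 nM, meaning an estimated 37-fold higher number from compound 1 to compound 4 (1.57 log units; beyond the scatter).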

Compound 4, half-maximal inhibitory concentration: 71 nM
Compound 4: the middle estimate sits 1.4-fold (0.15 log units) above what was measured; the range from low to high includes it.
By their numbers in this assay, from the lowest: compound 1; then compounds 2, 3 and 4 (each within the scatter of the next, the first and the last beyond it).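

The step of a 26-fold higher number from compound 1 to compound 4 (1.42 log units; beyond the scatter) in this assay shows that 4-methylpiperazin-1-yl, like the other non-aromatic rings on the sulfonyl sulfur, falls far short of 3-(trifluoromethyl)phenyl. With a 1.0-fold higher number from compound 3 to compound 4 (0.02 log units; within the scatter) the morpholin-4-yl and 4-methylpiperazin-1-yl groups cannot be told apart here, while a 2.0-fold higher number from compound 2 to compound 4 (0.31 log units; beyond the scatter) is only a modest separation from oxan-4-yl. Nothing available explains these differences. The compounds shown leave open whether the low number of compound 1 depends on the trifluoromethyl group or on the aromatic ring, which an unsubstituted phenyl or a pyridine ring on the sulfonyl sulfur would separate.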